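This account rests on a few compounds, and the source may have more. Where it says the series, first, only, none or still open, it means among the compounds named here.

Measured so far:
- compound 1 `O=C(Nc1cccc(-n2cc(-c3ccncc3)c(-c3cc(O)cc(Cl)c3)n2)c1)Nc1ccc(Cl)c(C(F)(F)F)c1` gives 91% in a functional assay on SF-295 cells (Homo sapiens) for inhibition, read by sulforhodamine B assay, with a stated time of 48 h, tested at 1 uM; a higher number here means a weaker effect of the compound at the concentration tested, a lower number a stronger effect
- compound 2 `O=C(Nc1cccc(-n2cc(-c3ccncc3)c(-c3cc(O)cc(Cl)c3)n2)c1)Nc1ccc(Cl)c(Cl)c1` gives 77% in this assay
- compound 3 `COc1cc(Cl)cc(-c2nn(-c3cccc(NC(=O)Nc4cc(C(F)(F)F)cc(C(F)(F)F)c4)c3)cc2-c2ccncc2)c1` gives 12% in this assay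

Among these three, compound 3 stands lowest, that is strongest, beyond the scatter from both others. Compound 4 `COc1cc(Cl)cc(-c2nn(-c3cccc(NC(=O)Nc4cccc(C(F)(F)F)c4)c3)cc2-c2ccncc2)c1` differs from compound 3 in one place: hydrogen in place of trifluoromethyl on an aromatic carbon. Within the data shown here, no measured step removes a trifluoromethyl outright; the only step touching that group, a number 14 percentage points lower from compound 1 to compound 2 (beyond the scatter), merely replaced it by chloro. Losing the group altogether in compound 4 is expected to cost more, so a rise in this assay is expected, with compound 4 estimated at 40% (range 15% to 80%), a step of a number 28 percentage points higher from compound 3 to compound 4 (beyond the scatter) expected.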

Compound 4, a percentage reported as activity, at one concentration (the size of the read-out at that concentration, not a potency): 45%
Estimate against measurement, compound 4: 5 percentage points below; measured number inside the range.
By their numbers in this assay, from the lowest: compound 3; then compound 4; then compound 2; then compound 1.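

Replacing one trifluoromethyl with hydrogen gives a number 33 percentage points higher from compound 3 to compound 4 (beyond the scatter) in this assay, a large weakening of the effect. This is the first step shown that removes the group outright rather than swapping it for chloro, and it shows that the effect depends on what occupies this aromatic carbon. Nothing measured here explains the change.

The compounds shown leave open whether a smaller or different group on this carbon, such as a nitrile or an amine, would keep the effect of compound 3.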